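A Trifluoromethyl Step Repeated on a Second Core

The source may hold more compounds than are shown below. What is called first, only, known or untested is meant among the compounds shown, and "the series" means these compounds.

Of the compounds shown here, three have been tested in a functional assay on PC-3 cells (Homo sapiens) for cytotoxicity, read by MTT assay, with a stated time of 72 h; on this read-out higher numbers stand for weaker inhibition and lower numbers for stronger inhibition. Compound 1 `CC1=CCCC(C)(C)C1/C=C/C(=O)/C=C/c1ccccc1F` gives 4800 nM in this assay. Compound 2 `CC1=CCCC(C)(C)C1/C=C/C(=O)/C=C/c1cc(C(F)(F)F)ccc1F` carries trifluoromethyl in place of hydrogen on an aromatic carbon and gives 3100 nM in this assay, a step of a 1.5-fold lower number from compound 1 to compound 2 (0.19 log units; within the scatter). Compound 3 `CC1=C(/C=C/C(=O)/C=C/c2ccccc2)C(C)(C)CCC1O` rests on a different core; how its core differs from that of compound 1 is not broken down here. In this assay compound 3 gives 15500 nM, the highest of the three numbers.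

Compound 4 `CC1=C(/C=C/C(=O)/C=C/c2ccccc2C(F)(F)F)C(C)(C)CCC1O` has not yet been measured. It differs from compound 3 by trifluoromethyl in place of hydrogen on an aromatic carbon. Among the measured compounds shown here, this is the same kind of change as the one made from compound 1 to compound 2, but the place is not the same: in compound 4 the group sits ortho to a large group, whereas in compound 2 it sits meta to a large group and para to a fluoro group. The expected step is therefore a 1.4-fold lower number from compound 3 to compound 4 (0.15 log units; within the scatter), resting on the earlier step of a 1.5-fold lower number from compound 1 to compound 2 (0.19 log units; within the scatter) that stayed within the scatter, with the different surroundings adding uncertainty. Compound 4 is accordingly estimated at 11000 nM in this assay, with a likely range from 5000 nM to 25000 nM.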

Compound 4, half-maximal inhibitory concentration: 3700 nM
Compound 4: the middle estimate sits 3.0-fold (0.47 log units) above what was measured; measured number below the stated range.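

In this assay, trifluoromethyl in place of hydrogen on an aromatic carbon gives a 4.2-fold lower number from compound 3 to compound 4 (0.62 log units; beyond the scatter) on the core of compound 3, and this step is clearly not the same as the one seen on the core of compound 1: the same change on two cores in this assay, a 1.5-fold lower number (0.19 log units; within the scatter) from compound 1 to compound 2 and a 4.2-fold lower number (0.62 log units; beyond the scatter) from compound 3 to compound 4, 2.7-fold (0.43 log units) apart, beyond the scatter of two such steps. The size of the step therefore did not carry over from one core to the other in these four compounds. This does not show that the core alone sets the gap: the group sits ortho to a large group in compound 4 but in a different place in compound 2, the pair on the core of compound 1 also carries a fluoro group, and with a single pair on each core these differences cannot be told apart.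

The compounds shown leave open whether trifluoromethyl at another place on the ring would give a step of similar size on the core of compound 3. They also leave open whether a chloro group, a methyl group or a nitrile in the same place would behave as trifluoromethyl does on either core.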